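One Fluorine Added to Compound 2: An Expectation

The source may report more compounds than this note shows. Statements on the series, on what has been measured and on what is new or still open speak of the compounds shown alone.

Among the measured compounds shown here, in a functional assay on HT-29 cells (Homo sapiens) for antiproliferative activity, read by MTT assay, with a stated time of 72 h (on this read-out lower numbers stand for stronger inhibition and higher numbers for weaker inhibition), compound 2 `COc1ccc(-n2c(=O)c(C(=O)Nc3ccc(Oc4ccnc5[nH]ccc45)cc3)cc3cccnc32)cc1` gives 1260 nM, the second highest of the three numbers measured so far. Compound 1 `O=C(Nc1ccc(Oc2ccnc3[nH]ccc23)cc1)c1cc2cccnc2n(-c2ccc(Cl)cc2)c1=O` gives 280 nM, and compound 3 `O=C(Nc1ccc(Oc2ccnc3[nH]ccc23)cc1)c1cc2cccnc2n(-c2ccc(Br)cc2F)c1=O` gives 2360 nM. The measured steps are a 4.5-fold higher number from compound 1 to compound 2 (0.65 log units; beyond the scatter), an 8.4-fold higher number from compound 1 to compound 3 (0.93 log units; beyond the scatter) and a 1.9-fold higher number from compound 2 to compound 3 (0.27 log units; within the scatter), and all three alter the group carried on the aromatic nitrogen of the shared core. Compound 4 `COc1ccc(-n2c(=O)c(C(=O)Nc3ccc(Oc4ccnc5[nH]ccc45)c(F)c3)cc3cccnc32)cc1` differs from compound 2 elsewhere: fluoro in place of hydrogen on an aromatic carbon, ortho to a large group and meta to a large group. For the measured compounds named here, no measured pair isolates this kind of change, so the steps above bear on it only indirectly; what they show is that single small changes have moved this assay by modest amounts or not beyond the scatter. With nothing pointing in a direction, the expected step is within the scatter. The estimated step from compound 2 to compound 4 is a 1.0-fold higher number from compound 2 to compound 4 (0.01 log units; within the scatter). Compound 4 is therefore expected to give 1300 nM, in an estimated range from 500 nM to 3500 nM.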

Compound 4, half-maximal inhibitory concentration: 540 nM
Compound 4: the middle estimate sits 2.4-fold (0.38 log units) above what was measured; the measured number falls inside the stated range.
By their numbers in this assay, from the lowest: compounds 1 and 4 (each within the scatter of the next); then compounds 2 and 3 (each within the scatter of the next).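

In this assay, among the compounds shown here, the earlier steps all altered the group on the aromatic nitrogen of the shared core, whereas this change lies elsewhere and still moves the number: fluoro in place of hydrogen on an aromatic carbon gives a 2.3-fold lower number from compound 2 to compound 4 (0.37 log units; beyond the scatter), a modest step beyond the scatter. This position, ortho to a large group and meta to a large group, therefore has a measurable effect on the read-out, even with a single added heavy atom that counts as neither a hydrogen-bond donor nor an acceptor. No available measurement bears on the reason for this step.

The compounds shown carry no chloro, methyl or amine at this position, so it remains open whether the lower number is particular to fluoro. On these data alone, it also remains open whether fluoro here would give a similar step with 4-chlorophenyl on the aromatic nitrogen.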